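A few compounds are considered here, and "the series" means these few. Any claim that something is new, unique, unknown or untested is made for them only; others in the source may bear on it.

Measured so far in an ADME assay on HEK-293T cells (Homo sapiens) for cytotoxicity, read by CCK-8 assay, with a stated time of 48 h; a higher number here means that more compound is tolerated, a lower number that less compound is tolerated:

- compound 1, `Cn1cc([S+]([O-])CC(=O)Nc2ccc(Cl)cc2)c2ccccc21`: in this assay compound 1 gives only a limit, > 100000 nM
- compound 2, `CCOc1ccccc1NC(=O)CSc1c[nH]c2ccc(OC)cc12`: in this assay compound 2 gives only a limit, > 100000 nM

Among the measured compounds shown here, compound 2 therefore stands at the top of what this assay resolves: no number, only a limit, and the one other value shown is a limit of the same kind (the limit of > 100000 nM in this assay, at which 2 of the 2 values shown sit). For the measured compounds named here, no pair of measured compounds differs in a single place, so no measured step is available to read a direction from.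

The next compound, compound 3 (`CCOc1ccccc1NC(=O)CSc1c[nH]c2ccc(Cl)cc12`), differs from compound 2 by chloro in place of methoxy on an aromatic carbon — chloro in place of methoxy on an aromatic carbon. With both shown values sitting at the limit, nothing points to a shift in either direction, and the expectation is no step beyond the usual scatter in this assay, most likely another limit. The expected step is a step that the limit leaves unreadable from compound 2 to compound 3. Compound 3 is expected to give about 150000 nM in this assay, within a range from 50000 nM to 500000 nM.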

Compound 3, half-maximal cytotoxic concentration: 37600 nM
For compound 3 the middle estimate is 4.0-fold (0.60 log units) above the measured one; measured number outside the range, below it.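

In this assay, chloro in place of methoxy, on an aromatic carbon meta to a fused ring and para to a fused ring, gives an at least 2.6-fold lower number from compound 2 to compound 3 (0.42 log units; beyond the scatter). Among the compounds shown here, this is the first sign that the position matters for how much compound is tolerated: the earlier compounds gave only limits, and compound 3 is the first to give a number inside the range that this assay resolves. The step can be stated only as a minimum because compound 2 gives a limit and no number: the limit of > 100000 nM in this assay, at which 2 of the 3 values shown sit.

On these data alone, whether the lower number belongs to chloro itself or to the loss of methoxy stays open, and a bare hydrogen, fluoro or an amine at the same place would separate those two readings. As far as these compounds go, compound 1 differs from compound 3 in more than one place, so it cannot be read against this change, and whether the same swap would lower the number on the core of compound 1 also remains open.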